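The compounds below may be only part of what the source reports. "The series", "measured", "known", "first", "only" and "open" are said of these compounds alone.

Working notes on the series.

Of the compounds shown here, two of the shared core have been measured in a functional assay on CHO cells with adenosine receptor A1 (Homo sapiens) as the target, read by cAMP accumulation and immunoassay, with a stated time of 6 min, tested at 0.01 uM; a higher number here means a weaker effect of the compound at the concentration tested, a lower number a stronger effect. Compound 1, `Nc1scc(CN2CCN(c3ccccc3F)CC2)c1C(=O)c1ccc(Cl)cc1`, gives 2.1%. Compound 2, `Nc1scc(CN2CCN(CCCc3ccc(Cl)cc3)CC2)c1C(=O)c1ccc(Cl)cc1`, gives 0%. On these two numbers compound 2 stands alongside compound 1: the step of a number 2.1 percentage points lower from compound 1 to compound 2 (within the scatter) is within the scatter, so neither compound can be called the stronger or the weaker, and both read as giving essentially no effect at the concentration tested.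

The next compound, compound 3, `Nc1scc(CN2CCN(c3ccccc3Cl)CC2)c1C(=O)c1ccc(Cl)cc1`, has not yet been measured. Its difference from compound 2 is 2-chlorophenyl in place of 3-(4-chlorophenyl)propyl on an amine nitrogen in a ring. For the measured compounds named here, the one measured step that bears on it is the step from compound 1 to compound 2, which swapped a 2-fluorophenyl for the 3-(4-chlorophenyl)propyl on the same ring nitrogen and produced no change beyond the scatter. Compound 3 carries a 2-chlorophenyl at that position, close to the group on compound 1, and compound 1 and compound 2 give the same low reading. No step beyond the scatter is therefore expected in this assay, as a number 2 percentage points higher from compound 2 to compound 3 (within the scatter).

Compound 3 is estimated at 2%, with a range from -5% to 10%.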

Compound 3, a percentage reported as activity, at one concentration (the size of the read-out at that concentration, not a potency): -2.1%
The estimate for compound 3 lay 4.1 percentage points above the measured number; measured number inside the range.
By their numbers in this assay, from the lowest: compounds 3, 2 and 1 (each within the scatter of the next).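

In this assay, 2-chlorophenyl in place of 3-(4-chlorophenyl)propyl on the amine nitrogen in the ring gives a number 2.1 percentage points lower from compound 2 to compound 3 (within the scatter), so this position now holds a second exchange between an aromatic ring on the nitrogen and the 3-(4-chlorophenyl)propyl chain without any change that can be read. The new pair adds the smallest change in the series, chloro in place of fluoro on an aromatic carbon, with the rest of the structure held constant, and it gives a number 4.2 percentage points lower from compound 1 to compound 3 (within the scatter), so in this assay the reading does not distinguish the two halogens at this place. The data offer no measurement that could explain why these three compounds read alike.

Still open, going by these compounds, is whether any group on this ring nitrogen can move the reading beyond the scatter, for example a carboxylic acid at the end of a propyl chain or a primary amine on the phenyl ring. The read-out comes from one concentration and is not a potency, so it also leaves open whether these compounds would separate at another concentration.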